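A chloro for fluoro swap on the shared core

This account rests on a few compounds, and the source may have more. Where it says the series, first, only, none or still open, it means among the compounds named here.

Compound 1 `CS(=O)(=O)c1ccc(Nc2nccc(Nc3nc4ccc(F)cc4s3)n2)cc1` gives 2080 nM in a functional assay on MDA-MB-231 cells (Homo sapiens) for antiproliferative activity, read by MTT assay, with a stated time of 48 h (a higher number here means a weaker inhibitor, a lower number a stronger inhibitor), the lowest of the two numbers recorded there. Compound 3 `CS(=O)(=O)c1ccc(Nc2ncc(F)c(Nc3nc4ccc(F)cc4s3)n2)cc1` gives 8900 nM in this assay, and the step of a 4.3-fold higher number from compound 1 to compound 3 (0.63 log units; beyond the scatter) is modest. Compound 2 `Cc1cnc(Nc2ccc(S(C)(=O)=O)cc2)nc1Nc1nc2ccc(F)cc2s1` sits at the limit of > 50000 nM in this assay, at which 1 of the 3 values shown sits, and its value in this assay, > 50000 nM, is a limit and not a number. The step of an at least 24-fold higher number from compound 1 to compound 2 (1.38 log units; beyond the scatter) is accordingly large, and the step of an at least 5.6-fold lower number from compound 2 to compound 3 (0.74 log units; beyond the scatter) is at least modest.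

Compound 4 `CS(=O)(=O)c1ccc(Nc2nccc(Nc3nc4ccc(Cl)cc4s3)n2)cc1` differs from compound 1 in one place: chloro in place of fluoro on an aromatic carbon. For the measured compounds named here, none of the measured steps touches this position; all three exchange a hydrogen, a methyl or a fluoro on a different part of the shared core, and so they carry little weight for a chloro in place of fluoro here. Going by the values given here, with no measured step bearing directly on the change, the expectation for compound 4 in this assay rests on compound 1 alone, and the step of a 1.4-fold lower number from compound 1 to compound 4 (0.14 log units; within the scatter) is estimated to fall within the scatter or close to it. Compound 4 is therefore expected to give 1500 nM in this assay, within a range of 500 nM to 6000 nM.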

Compound 4, half-maximal inhibitory concentration: > 50000 nM
Compound 4 ended at the assay's limit; the forecaster's own chance of this, stated with the estimate: 5%; middle value at least 33-fold (1.52 log units) from the limit.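

For the compounds shown here, this is the first step that touches the halogen on the six-membered aromatic ring of carbon only, the part of the shared core that the earlier exchanges of hydrogen, methyl and fluoro left alone, and in this assay the step of an at least 24-fold higher number from compound 1 to compound 4 (1.38 log units; beyond the scatter) shows that this position is far from indifferent to chloro in place of fluoro. For compound 4 the value > 50000 nM is a limit of the assay and not a number. A swap of one halogen atom here thus moves compound 1 as far as methyl in place of hydrogen did on a different part of the core, and neither step can be sized any further: the limit of > 50000 nM in this assay, at which 2 of the 4 values shown sit.

The compounds shown leave open how a bromo, a methoxy, an amine or a plain hydrogen in place of the fluoro would read in this assay, so it cannot be said whether fluoro alone is accepted at this position. They also leave open whether chloro here would give the same result on a core that carries the fluoro of compound 3 on its other part.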